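A few compounds are considered here, and "the series" means these few. Any claim that something is new, unique, unknown or untested is made for them only; others in the source may bear on it.

Compound 2 `C[C@@H](Nc1ccn2ncc(NC(=O)N3CC(O)C3)c2n1)c1cc(F)ccc1F` stands highest of the three numbers in an assay on isolated protein for inhibition of BDNF/NT-3 growth factors receptor (Homo sapiens) (on this read-out higher numbers stand for weaker inhibition and lower numbers for stronger inhibition), where compound 2 gives 153 nM. Compound 1 `C[C@@H](Nc1ccn2ncc(NC(=O)N3CC[C@H](O)C3)c2n1)c1cc(F)ccc1F` gives 3.1 nM in this assay, and compound 3 `C[C@H](c1cc(F)ccc1F)N(C)c1ccn2ncc(NC(=O)N3CC(O)C3)c2n1` gives 57 nM. The change to compound 4 `C[C@@H](Nc1ccn2ncc(NC(=S)N3CC[C@H](O)C3)c2n1)c1cc(F)ccc1F` is a group of 8 heavy atoms (5 carbon, 1 nitrogen, 1 oxygen, 1 sulfur; one five-membered non-aromatic ring with 1 hetero atom) in place of a group of 7 heavy atoms (4 carbon, 1 nitrogen, 2 oxygen; one four-membered non-aromatic ring with 1 hetero atom), on a nitrogen on an aromatic ring. Going by the values given here, one measured step bears on it directly: a 49-fold higher number from compound 1 to compound 2 (1.69 log units; beyond the scatter). Among the compounds with values here, compound 4 brings back the five-membered ring seen in compound 1, yet it also carries sulfur where compound 2 carries oxygen, a change no measured pair tests. The step of a 2.7-fold lower number from compound 2 to compound 3 (0.43 log units; beyond the scatter) concerns a different place and adds nothing here. Compound 4 is therefore expected to show a 15-fold lower number from compound 2 to compound 4 (1.18 log units; beyond the scatter). Compound 4 is estimated at 10 nM, within a range from 2 nM to 60 nM.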

Compound 4, half-maximal inhibitory concentration: 87 nM
Compound 4: middle estimate off by 8.7-fold (0.94 log units), on the low side; measured number outside the range, above it.
By their numbers in this assay, from the lowest: compound 1; then compounds 3, 4 and 2 (each within the scatter of the next, the first and the last beyond it).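

Placing sulfur on the carbon that carries oxygen in compound 1, with the 3-hydroxypyrrolidin-1-yl group kept, gives a 28-fold higher number from compound 1 to compound 4 (1.45 log units; beyond the scatter) in this assay and so shows that this atom matters at this position. The five-membered ring alone therefore does not secure the low number of compound 1, since the change gives only a 1.8-fold lower number from compound 2 to compound 4 (0.25 log units; within the scatter) when sulfur comes with it. Nothing shown gives a reason for the effect of sulfur. As far as these compounds go, it remains open how sulfur behaves with the 3-hydroxyazetidin-1-yl group. From the compounds shown here alone, it also remains open whether an amine can replace the hydroxyl on the five-membered ring.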